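A few compounds are considered here, and "the series" means these few. Any claim that something is new, unique, unknown or untested is made for them only; others in the source may bear on it.

Of the compounds shown here, two built on the same core have been measured in an in vitro functional assay on cells (Fibroblast) for agonist activity at Alpha-1D adrenergic receptor (Homo sapiens); on this read-out higher numbers stand for an effect only at larger amounts of compound and lower numbers for an effect already at smaller amounts. Compound 1 `CCCn1ncnc1-c1ccccc1NCC1=NCCN1` gives 251 nM in this assay. Compound 2 `c1ccc(-c2nc[nH]n2)c(NCC2=NCCN2)c1` gives 3.98 nM in this assay, the lower of the two numbers; the number for compound 1 is higher by a margin that lies beyond the usual scatter of repeated measurements. For the measured compounds named here, no pair of these measured compounds differs in only one place, so no single step between measured compounds can be read from them.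

Compound 3 `Cn1ccc(-c2ccccc2NCC2=NCCN2)n1` has not yet been measured in this assay. It differs from compound 2 in one place: 1-methyl-1H-pyrazol-3-yl in place of 1H-1,2,4-triazol-3-yl on an aromatic carbon. Compound 2 stands at the lower end of what is known so far, and the change exchanges the group that carries the ring with three hetero atoms for one with two. The expected step is a 10-fold higher number from compound 2 to compound 3 (1.00 log units; beyond the scatter), toward higher numbers, and probably beyond the scatter, though a small step cannot be ruled out. Compound 3 is accordingly estimated at 40 nM, with a range from 8 nM to 200 nM.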

Compound 3, half-maximal effective concentration: 15.9 nM
Compound 3: the middle estimate sits 2.5-fold (0.40 log units) above what was measured; the range from low to high includes it.
By their numbers in this assay, from the lowest: compound 2; then compound 3; then compound 1.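

In this assay, for the compounds shown here, the exchange gives the only step in this set that can be read at a single place: a 4.0-fold higher number from compound 2 to compound 3 (0.60 log units; beyond the scatter), a modest step that lies beyond the usual scatter. It shows that, on an aromatic carbon ortho to a group of 7 heavy atoms, replacing 1H-1,2,4-triazol-3-yl with 1-methyl-1H-pyrazol-3-yl moves the number upward without a very large change, although the entering group has one five-membered aromatic ring with 2 hetero atoms rather than 3, 0 hydrogen-bond donors rather than 1, and the same count of 2 hydrogen-bond acceptors. No measurement here bears on why the number rises with this change.

The compounds shown leave open which of these differences carries the step, as the ring and the methyl group change together in this single pair. From the compounds shown here alone, a 1H-pyrazol-3-yl group without the methyl or a 1-methyl-1H-1,2,4-triazol-3-yl group would separate those two changes, and the outcome with a group outside this ring type, such as an amine or a carboxylic acid, on the same aromatic carbon also remains open.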